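Removing the ortho methoxy: from compound 3 to compound 4

The source may hold more compounds than are shown below. What is called first, only, known or untested is meant among the compounds shown, and "the series" means these compounds.

Measured compounds:
compound 1, `CCC1(CCCCN2CCN(c3ccc(F)c(Cl)c3)CC2)C(=O)Nc2ccccc21`: > 20 mg/kg
compound 2, `CCC1(CCCCN2CCN(c3ccc(OC)cc3)CC2)C(=O)Nc2ccccc21`: > 20 mg/kg
compound 3, `CCC1(CCCCN2CCN(c3ccccc3OC)CC2)C(=O)Nc2ccccc21`: 10 mg/kg

In a functional assay on the whole organism (strain Wistar) with Rattus norvegicus as the target, with a stated time of 5 min (a higher number here means that more compound is needed for the effect, a lower number that less compound is needed), compound 1 reaches only a limit of the assay, > 20 mg/kg. For compound 2 the same limit is recorded, > 20 mg/kg. Going by the values given here, compound 3 is the one compound with a proper number, 10 mg/kg, so it stands apart as the only measured point in this assay.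

Compound 4, `CCC1(CCCCN2CCN(c3ccccc3)CC2)C(=O)Nc2ccccc21`, has not been measured. It differs from compound 3 by hydrogen in place of methoxy on an aromatic carbon.

Among the compounds with values here, no measured step removes the methoxy outright. The nearest guides are an at least 2.0-fold lower number from compound 2 to compound 3 (0.30 log units; that floor lies within the scatter) and an at least 2.0-fold lower number from compound 1 to compound 3 (0.30 log units; that floor lies within the scatter), both reading as steps of at least that size, whose floor lies within the scatter. Within the data shown here, they point the same way: the 2-methoxyphenyl carries the only number seen, and every other aryl group sits at the limit (the limit of > 20 mg/kg in this assay, at which 2 of the 3 values shown sit). Taking the methoxy away therefore seems more likely to push the number up than down, with a fair chance of landing at the limit again.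

Compound 4 is estimated at 20 mg/kg in this assay, with a range from 8 mg/kg to 50 mg/kg. That estimate means an expected step of a 2.0-fold higher number from compound 3 to compound 4 (0.30 log units; within the scatter).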

Compound 4, minimum effective dose: 10 mg/kg
Estimate against measurement, compound 4: 2.0-fold (0.30 log units) above; low and high end bracket the measured number.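

In this assay, going by these compounds alone, the methoxy at this place turns out not to be needed for a measurable dose, with no change at the digits printed from compound 3 to compound 4 (within the scatter), so the 2-methoxyphenyl no longer stands alone as the only aryl group giving a real number. The plain phenyl can also be set against the two substituted rings that gave no number, with an at least 2.0-fold lower number from compound 2 to compound 4 (0.30 log units; that floor lies within the scatter) for the 4-methoxyphenyl and an at least 2.0-fold lower number from compound 1 to compound 4 (0.30 log units; that floor lies within the scatter) for the 3-chloro-4-fluorophenyl, although the true size of these steps stays hidden. Among these four compounds, only the 4-methoxyphenyl and the 3-chloro-4-fluorophenyl fail to give a number, so the bare ring is enough and only those two substituted rings fall short of a number: the limit of > 20 mg/kg in this assay, at which 2 of the 4 values shown sit.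

From the compounds shown here alone, what a different group on the same ring carbon would do remains open, for example a hydroxy, a chlorine or a methyl in place of the methoxy. Also open, going by these compounds, is whether a shorter or longer chain between the core and the ring nitrogen would bring the dose below that shared by compound 3 and compound 4.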